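The source may report more compounds than this note shows. Statements on the series, on what has been measured and on what is new or still open speak of the compounds shown alone.

Working notes on the series. In a functional assay on DLD-1 cells (Homo sapiens) for antiproliferative activity, read by CellTiter-Glo, with a stated time of 72 h (a lower number here means a stronger inhibitor, a higher number a weaker inhibitor), compound 1 (`CC1CCN(C2CCN(S(=O)(=O)c3cccnc3)CC2)CC1`) gives 2400 nM and compound 2 (`CC1CCN(C2CCN(S(=O)(=O)c3cc(Cl)cc(Cl)c3)CC2)CC1`) gives 3400 nM (the two values lie within the scatter of each other). For the measured compounds named here, compound 2 therefore has compound 1 as its only neighbour on these numbers. Compound 3 (`CC1CCN(C2CCN(S(=O)(=O)c3ccc(Cl)cc3Cl)CC2)CC1`) arises from compound 2 by the change 2,4-dichlorophenyl in place of 3,5-dichlorophenyl on a sulfonyl sulfur, with the same atoms joined differently. Going by the values given here, one measured step bears on it, a 1.4-fold higher number from compound 1 to compound 2 (0.15 log units; within the scatter) at the same place, and that step lies within the scatter. Among the compounds with values here, no measured compound carries 2,4-dichlorophenyl, so the data give no direction, and no step beyond the scatter is expected in this assay for this change. The expected step is a 1.1-fold lower number from compound 2 to compound 3 (0.05 log units; within the scatter) (an estimate only). For compound 3 the estimated value is 3000 nM with an expected range from 1300 nM to 7000 nM (not yet a measurement).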

Compound 3, half-maximal inhibitory concentration: 1 nM
Compound 3: the middle estimate sits 3000-fold (3.48 log units) above what was measured; the measured number lies below the stated range.
By their numbers in this assay, from the lowest: compound 3; then compounds 1 and 2 (each within the scatter of the next).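

In this assay, this place on the sulfonyl sulfur turns out to be highly sensitive to how the two chlorines are arranged on the phenyl ring: with the same atoms joined differently, 2,4-dichlorophenyl in place of 3,5-dichlorophenyl gives a 3400-fold lower number from compound 2 to compound 3 (3.53 log units; beyond the scatter). The same group in place of pyridin-3-yl gives a 2400-fold lower number from compound 1 to compound 3 (3.38 log units; beyond the scatter), whereas the earlier exchange at this place, a 1.4-fold higher number from compound 1 to compound 2 (0.15 log units; within the scatter), gave no sign of such sensitivity. No measurement at hand accounts for the size of these steps.

As far as these compounds go, it remains open whether the step requires both chlorines, and whether 2,4-difluorophenyl or 2,4-dimethylphenyl on the sulfonyl sulfur would retain it. From the compounds shown here alone, it is also open whether the step survives a change elsewhere in the shared core, such as the addition of a carboxylic acid.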